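The compounds below may be only part of what the source reports. "The series", "measured", "known", "first", "only" and "open" are said of these compounds alone.

Three compounds share one core: compound 1 `Cc1ccsc1-c1ncnc2c1ncn2C1O[C@H](CO)[C@@H](O)[C@H]1O`, compound 2 `Cn1cccc1-c1ncnc2c1ncn2C1O[C@H](CO)[C@@H](O)[C@H]1O` and compound 3 `OC[C@H]1OC(n2cnc3c(-c4nccs4)ncnc32)[C@H](O)[C@@H]1O`. In a functional assay on CCRF-CEM cells (Homo sapiens) for inhibition (on this read-out higher numbers stand for weaker inhibition and lower numbers for stronger inhibition), compound 1 gives 2500 nM, compound 2 gives 2000 nM and compound 3 gives 2730 nM. The three numbers sit within the usual scatter of one another: a 1.3-fold lower number from compound 1 to compound 2 (0.10 log units; within the scatter), a 1.1-fold higher number from compound 1 to compound 3 (0.04 log units; within the scatter) and a 1.4-fold higher number from compound 2 to compound 3 (0.14 log units; within the scatter). Compound 3 therefore stands level with the other two on the numbers shown.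

Compound 4 `OC[C@H]1OC(n2cnc3c(-c4cc5ccccc5o4)ncnc32)[C@H](O)[C@@H]1O` differs from compound 3 in one place: 1-benzofuran-2-yl in place of 1,3-thiazol-2-yl on an aromatic carbon. The measured steps that bear on this are the exchanges of one five-membered aromatic group for another, a 1.1-fold higher number from compound 1 to compound 3 (0.04 log units; within the scatter) and a 1.4-fold higher number from compound 2 to compound 3 (0.14 log units; within the scatter), both within the scatter. Among the measured compounds shown here, no measured step brings in a group carrying a second, fused six-membered ring, so the reach of this change is untested here. On that basis no step beyond the scatter is expected in this assay, with the range kept wide for the untested part: a 1.1-fold lower number from compound 3 to compound 4 (0.04 log units; within the scatter). Compound 4 is expected to give about 2500 nM, between 800 nM and 8000 nM.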

Compound 4, half-maximal inhibitory concentration: 15000 nM
Compound 4: the middle estimate sits 6.0-fold (0.78 log units) below what was measured; the whole stated range lies below it.
By their numbers in this assay, from the lowest: compounds 2, 1 and 3 (each within the scatter of the next); then compound 4.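

In this assay the position on the shared core proves sensitive to the group it carries: the three groups with a single five-membered aromatic ring stand level, while 1-benzofuran-2-yl, with its added six-membered aromatic ring of carbon only, reads weaker in every comparison (a 5.5-fold higher number from compound 3 to compound 4 (0.74 log units; beyond the scatter)) and (a 7.5-fold higher number from compound 2 to compound 4 (0.88 log units; beyond the scatter)) and (a 6.0-fold higher number from compound 1 to compound 4 (0.78 log units; beyond the scatter)). Of the four groups shown, only this fused one moves the number beyond the scatter, and the shift is modest. Nothing available explains the loss.

The compounds shown do not separate the added ring from the exchange of hetero atoms within the five-membered ring. On these data alone, how a plain phenyl, or a five-membered aromatic group carrying an amine or a carboxylic acid, would read at this position stays open.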